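A few compounds are considered here, and "the series" means these few. Any claim that something is new, unique, unknown or untested is made for them only; others in the source may bear on it.

Measured compounds in an assay on isolated protein (Mus musculus) for inhibition of IL15-IL15 receptor (Homo sapiens), read by resazurin assay, with stated times of 30 min and 2.5 days; on this read-out higher numbers stand for weaker inhibition and lower numbers for stronger inhibition:
compound 1 `Cn1c(Cc2nn(C)c(=O)c3ccccc23)nnc1SCCCCCCCC(=O)Nc1ccc(Cl)cc1` gives 800 nM
compound 2 `Cn1c(Cc2nn(C)c(=O)c3ccccc23)nnc1SCCCCCCCC(=O)Nc1ccc(O)cc1` gives > 30000 nM, a limit of the assay rather than a number
compound 3 `Cn1c(Cc2nn(C)c(=O)c3ccccc23)nnc1SCCCCCCCCCCC(=O)Nc1ccc(Cl)cc1` gives 20000 nM

Within the data shown here, compound 3 holds the highest of the two numbers in this assay; compound 1 gives a lower number, and these two differ in the length of the chain between the sulfur and the amide, a pair for which no single step is set out here. Compound 2 stands only at the limit described by the limit of > 30000 nM in this assay, at which 1 of the 3 values shown sits.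

Compound 4 `CCCCCCCCCCSc1nnc(Cc2nn(C)c(=O)c3ccccc23)n1C` is to be measured in this assay. It differs from compound 3 by hydrogen in place of (4-chlorophenyl)carbamoyl on a saturated chain carbon, ten or more bonds along the chain from a sulfur. Among the measured compounds shown here, the one measured step that bears on this end of the molecule is an at least 37-fold higher number from compound 1 to compound 2 (1.57 log units; beyond the scatter): a change of the substituent on the aryl ring alone raised the number strongly. Taking away the whole (4-chlorophenyl)carbamoyl group is a more sweeping change at the same end, so a further rise in this assay is expected, from a starting point already close to the limit. Compound 4 is therefore estimated at 60000 nM (range 15000 nM to 250000 nM), with a good chance that only the limit is returned. The expected step is a 3.0-fold higher number from compound 3 to compound 4 (0.48 log units; beyond the scatter).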

Compound 4, half-maximal inhibitory concentration: 7600 nM
The estimate for compound 4 lay 7.9-fold (0.90 log units) above the measured number; the measured number lies below the stated range.
By their numbers in this assay, from the lowest: compound 1; then compound 4; then compound 3. At a limit, above all of these: compound 2.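

In this assay, the (4-chlorophenyl)carbamoyl group is not required for a measurable number: removing it from the longer chain gives a 2.6-fold lower number from compound 3 to compound 4 (0.42 log units; beyond the scatter), so on this chain the unsubstituted alkyl end of compound 4 outperforms the amide end of compound 3. The same end group is favourable in the shorter-chain setting, where replacing it with propyl gives a 9.5-fold higher number from compound 1 to compound 4 (0.98 log units; beyond the scatter), so compound 1 keeps the lowest number shown and the value of the group is not the same in compound 1 and compound 3. Compound 2 is held at a limit of the assay, not a number, yet its (4-hydroxyphenyl)carbamoyl end compares poorly with the propyl extension, as an at least 3.9-fold lower number from compound 2 to compound 4 (0.59 log units; beyond the scatter) shows, and this step is only a bound: the limit of > 30000 nM in this assay, at which 1 of the 4 values shown sits.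

The compounds shown leave open how the number for an unsubstituted alkyl chain changes with length, as a shorter alkyl chain would show. On these data alone, it also remains open whether a carboxylic acid or a primary amine at the chain end would behave like the alkyl end of compound 4 or like the amide end of compound 1.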